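The source may report more compounds than this note shows. Statements on the series, on what has been measured and on what is new or still open speak of the compounds shown alone.

Measured compounds:
- compound 1, `O=C(/C=C/c1cccnc1)NCCCCCCc1ccc(S(=O)(=O)Nc2ccccc2)cc1`, gives 14.4 nM
- compound 2, `O=C(/C=C/c1cccnc1)NCCCCCCCc1ccc(S(=O)(=O)Nc2ccccc2)cc1`, gives 16.4 nM
- compound 3, `Cc1cccc(NS(=O)(=O)c2cccc(CCCCCCNC(=O)/C=C/c3cccnc3)c2)c1`, gives 12.3 nM

All three numbers come from an assay on isolated protein for inhibition of Nicotinamide phosphoribosyltransferase (Homo sapiens), read by WST assay, with stated times of 60 min, 5 min and 30 min, in the presence of a further agent that is not named here; a lower number here means a stronger inhibitor, a higher number a weaker inhibitor. Compound 3 has the lowest of the three numbers, but its nearest neighbour, compound 1, and its furthest, compound 2, both sit within the usual scatter of the measurement, so the three compounds cannot be told apart on these data.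

Compound 4, `O=C(/C=C/c1cccnc1)NCCCCCCc1cccc(S(=O)(=O)Nc2ccc(F)cc2)c1`, has not yet been measured. It differs from compound 3 in one place: 4-fluorophenyl in place of 3-methylphenyl on a sulfonamide nitrogen. For the measured compounds named here, no measured pair shows the effect of such a swap on this series, so the expectation for compound 4 rests only on the closeness of the three measured numbers and on the small size of the change. The author expects no step beyond the scatter, with the step from compound 3 to compound 4 estimated at a 1.2-fold higher number from compound 3 to compound 4 (0.09 log units; within the scatter). Compound 4 is therefore expected to give about 15 nM in this assay, within a range from 7 nM to 35 nM.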

Compound 4, half-maximal inhibitory concentration: 9.2 nM
Estimate against measurement, compound 4: 1.6-fold (0.21 log units) above; the range from low to high includes it.
By their numbers in this assay, from the lowest: compounds 4, 3, 1 and 2 (each within the scatter of the next).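

In this assay, for the compounds shown here, the first comparison that differs in only one place gives a 1.3-fold lower number from compound 3 to compound 4 (0.13 log units; within the scatter), so this step does not separate the two compounds. On the sulfonamide nitrogen, then, 4-fluorophenyl and 3-methylphenyl are not told apart by this measurement, although the swap changes both the substituent and its place on the phenyl ring, and this single step cannot divide the two changes. Nothing measured here bears on what lies behind the step.

The compounds shown leave open whether this nitrogen would accept a group of a different kind, such as a phenyl ring carrying a carboxylic acid or an amine. They also leave open what a simple methyl on this nitrogen, with no phenyl ring, would give.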